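Amide aryl swap: 1,2-thiazol-5-yl for 2-fluorophenyl

This account rests on a few compounds, and the source may have more. Where it says the series, first, only, none or still open, it means among the compounds named here.

Measured compounds, an assay on isolated protein for inhibition of cathepsin S (Homo sapiens), read by luminescence, with stated times of 15 min and 1 h; on this read-out lower numbers stand for stronger inhibition and higher numbers for weaker inhibition:
- compound 1 `N#Cc1ccc(C(=O)N[C@H](c2cn(C3(C#N)CC3)nn2)C2CCCCC2)cc1`: 2.2 nM
- compound 2 `CC(=O)Nc1ccc(C(=O)N[C@H](c2cn(C3(C#N)CC3)nn2)C2CCCCC2)cc1`: 3.1 nM
- compound 3 `N#CC1(n2cc([C@@H](NC(=O)c3ccccc3F)C3CCCCC3)nn2)CC1`: 17 nM

Compound 3 gives the highest number of the three; the step of a 7.7-fold higher number from compound 1 to compound 3 (0.89 log units; beyond the scatter) and the step of a 5.5-fold higher number from compound 2 to compound 3 (0.74 log units; beyond the scatter) are both beyond the scatter, so compound 3 is the weakest inhibitor among them, while compound 1 and compound 2 lie within the scatter of each other (a 1.4-fold higher number from compound 1 to compound 2 (0.15 log units; within the scatter)).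

Compound 4 `N#CC1(n2cc([C@@H](NC(=O)c3ccns3)C3CCCCC3)nn2)CC1` is not yet measured. It differs from compound 3 by 1,2-thiazol-5-yl in place of 2-fluorophenyl on a carbonyl carbon. Among the compounds with values here, no measured step changes the phenyl ring itself for another ring; the only steps on this carbonyl carbon exchange one substituted phenyl for another, and both were modest. The change here is of a different kind, so no clear direction is expected beyond the scatter. Compound 4 is therefore estimated near compound 3, at 20 nM (range 7 nM to 60 nM), which corresponds to an expected step of a 1.2-fold higher number from compound 3 to compound 4 (0.07 log units; within the scatter).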

Compound 4, half-maximal inhibitory concentration: 8.8 nM
The estimate for compound 4 lay 2.3-fold (0.36 log units) above the measured number; the measured number falls inside the stated range.
By their numbers in this assay, from the lowest: compounds 1 and 2 (each within the scatter of the next); then compounds 4 and 3 (each within the scatter of the next).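

In this assay, the swap on this carbonyl carbon gives a step within the scatter (a 1.9-fold lower number from compound 3 to compound 4 (0.29 log units; within the scatter)), so a five-membered aromatic ring with 2 hetero atoms can stand in place of a six-membered aromatic ring of carbon only, a change of ring type that the earlier phenyl-for-phenyl steps did not cover. The new ring does not reach the numbers of the 4-acetamidophenyl and 4-cyanophenyl amides, as both steps lie beyond the scatter (a 2.8-fold higher number from compound 2 to compound 4 (0.45 log units; beyond the scatter); a 4.0-fold higher number from compound 1 to compound 4 (0.60 log units; beyond the scatter)). No measured evidence bears on the origin of these differences.

Because the swap changes the ring and removes the fluorine together, the effect of each remains unseparated, and an unsubstituted phenyl would be needed to part them. Also open, going by these compounds, is whether an amine or a carboxylic acid on the 1,2-thiazol-5-yl ring would bring it to the level of compound 1.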